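Vero cytotoxicity notes: methoxy added to the aryl ring

This account rests on a few compounds, and the source may have more. Where it says the series, first, only, none or still open, it means among the compounds named here.

Measured so far:
Compound 1 `COc1cc(/C(Cl)=C/C=C(\C#N)C(=O)c2c[nH]c3ccccc23)cc(OC)c1OC` gives 35900 nM
Compound 2 `COc1ccc(/C(Cl)=C/C=C(\C#N)C(=O)c2c(C)[nH]c3ccccc23)cc1OC` gives 41100 nM

Both values come from an ADME assay on Vero cells (Chlorocebus sabaeus) for cytotoxicity, read by sulforhodamine B assay, with a stated time of 48 h; a higher number here means a weaker inhibitor of growth, a lower number a stronger inhibitor of growth. Compound 2 has the highest of the two numbers, but its nearest neighbour, compound 1, lies within the usual scatter of repeated measurements, so the two cannot be told apart on these data and no order between them is claimed.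

The next compound in the series is compound 3 `COc1cc(/C(Cl)=C/C=C(\C#N)C(=O)c2c(C)[nH]c3ccccc23)cc(OC)c1OC`. It differs from compound 2 in one place: methoxy in place of hydrogen on an aromatic carbon. Among the measured compounds shown here, no pair of measured compounds differing in a single place is available, so no measured step can be quoted for this change. For the measured compounds named here, the only comparable information is that compound 1 and compound 2, which differ in two places, give numbers within the scatter of each other; this gives no reason to expect a large move in this assay.

The step from compound 2 to compound 3 is therefore expected to be small, a 1.0-fold lower number from compound 2 to compound 3 (0.01 log units; within the scatter), with no direction claimed beyond the scatter. Compound 3 is accordingly estimated at 40000 nM, with a range of 18000 nM to 90000 nM.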

Compound 3, concentration for total growth inhibition: 42600 nM
Beside the measured number, compound 3's estimate is 1.1-fold (0.03 log units) below it; measured number inside the range.
By their numbers in this assay, from the lowest: compounds 1, 2 and 3 (each within the scatter of the next).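

In this assay, methoxy in place of hydrogen, on an aromatic carbon ortho to a methoxy group and meta to a large group, gives a 1.0-fold higher number from compound 2 to compound 3 (0.02 log units; within the scatter), so this added methoxy leaves the number indistinguishable from that of compound 2. Among the compounds shown here, compound 3 also supplies the first single-place comparison for an added methyl, a 1.2-fold higher number from compound 1 to compound 3 (0.07 log units; within the scatter), so the two changes that separate compound 1 from compound 2 can now be read singly through compound 3, and neither step lies beyond the scatter. Nothing in hand bears on why these steps are this small.

These two steps cover only methoxy and methyl, each on a single background, so they do not show whether the flat result extends to a different kind of group, such as an amine or a carboxylic acid, on the same aromatic carbon. As far as these compounds go, it also remains open whether a longer chain, such as ethoxy in place of methoxy or propyl in place of methyl, would stay within the scatter of compound 3.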